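A larger group on the amide-type ring nitrogen

The compounds below may be only part of what the source reports. "The series", "measured", "known", "first", "only" and "open" are said of these compounds alone.

Compound 1 `COc1cc(-c2nc3cc(/C=C4\SC(=O)NC4=O)ccc3[nH]2)cc(OC)c1OC` in an ADME assay on HEK-293T cells (Homo sapiens) for inhibition, read by MTT assay, with a stated time of 48 h; on this read-out lower numbers stand for stronger inhibition and higher numbers for weaker inhibition: 13600 nM
Compound 2 `COc1ccc(-c2nc3cc(/C=C4\SC(=O)NC4=O)ccc3[nH]2)cc1OC` in this assay: 21700 nM

Going by the values given here, compound 1 holds the lower of the two numbers, with compound 2 as its only neighbour; the step of a 1.6-fold higher number from compound 1 to compound 2 (0.20 log units; within the scatter) is within the scatter, so the two cannot be ordered. Compound 3 `COc1cc(-c2nc3cc(/C=C4\SC(=O)N(CC(=O)N5CCOCC5)C4=O)ccc3[nH]2)cc(OC)c1OC` is derived from compound 1 by the change (((morpholin-4-yl)carbonyl)methyl in place of hydrogen on an amide-type nitrogen in a ring). Among the compounds with values here, no measured step touches this position: the one step available, a 1.6-fold higher number from compound 1 to compound 2 (0.20 log units; within the scatter), concerns a methoxy on an aromatic carbon and says nothing about what happens on the amide-type nitrogen in the five-membered ring. Within the data shown here, with no step that bears on it, the expectation for compound 3 rests on compound 1 alone. Compound 3 is therefore estimated at 14000 nM, with a range from 4500 nM to 45000 nM. That estimate means a step of a 1.0-fold higher number from compound 1 to compound 3 (0.01 log units; within the scatter), expected to stay within the scatter, with the range kept wide to admit a real shift in either direction.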

Compound 3, half-maximal inhibitory concentration: 18800 nM
Estimate against measurement, compound 3: 1.3-fold (0.13 log units) below; low and high end bracket the measured number.
By their numbers in this assay, from the lowest: compounds 1, 3 and 2 (each within the scatter of the next).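

In this assay, the swap of hydrogen for ((morpholin-4-yl)carbonyl)methyl on the amide-type nitrogen gives a 1.4-fold higher number from compound 1 to compound 3 (0.14 log units; within the scatter), so this replacement cannot be told apart from repeat measurement. Going by these compounds alone, the only earlier step concerned a methoxy on an aromatic carbon, so this is the first reading at this nitrogen, and it shows that here the amide hydrogen can give way to this group, with its six-membered non-aromatic ring, without a measurable shift. No measurement is available that would account for this result.

From the compounds shown here alone, whether a smaller methyl, a longer alkyl chain, a carboxylic acid or a piperazine amine on the same nitrogen would also stay within the scatter remains open. Going by these compounds, it is equally open whether the same replacement on compound 2 would behave as it does on compound 1.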